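This account rests on a few compounds, and the source may have more. Where it says the series, first, only, none or still open, it means among the compounds named here.

Measured so far:
- compound 1, `O=C(Nc1ccccc1)c1cc(Oc2ccc(/C=C/c3ccncc3)cc2)ccn1`: > 100000 nM
- compound 2, `COc1ccc(NC(=O)c2cc(Oc3ccc(/C=C/c4ccncc4)cc3)ccn2)cc1`: > 100000 nM
- compound 3, `O=C(NCc1ccccc1)c1cc(Oc2ccc(/C=C/c3ccncc3)cc2)ccn1`: 28900 nM

All three were tested in a functional assay on HepG2 cells (Homo sapiens) for antiproliferative activity, read by CCK-8 assay, with a stated time of 48 h; on this read-out higher numbers stand for weaker inhibition and lower numbers for stronger inhibition. For compound 1 the value > 100000 nM is a limit of the assay, not a number. For compound 2 the value > 100000 nM is likewise a limit. Compound 3 is the only one of the three with a real number, 28900 nM.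

Compound 3 differs from compound 1 by benzyl in place of phenyl on an amide-type nitrogen; this change gave an at least 3.4-fold lower number from compound 1 to compound 3 (0.53 log units; beyond the scatter). Compared with compound 2 the same compound shows an at least 3.4-fold lower number from compound 2 to compound 3 (0.53 log units; beyond the scatter). The change from compound 1 to compound 2 is methoxy in place of hydrogen on an aromatic carbon, and its step, a step that the two limits leave unreadable from compound 1 to compound 2, cannot be sized because both compounds sit at the limit of > 100000 nM in this assay, at which 2 of the 3 values shown sit.

Compound 4, `COc1ccc(CNC(=O)c2cc(Oc3ccc(/C=C/c4ccncc4)cc3)ccn2)cc1`, has not been measured. For the measured compounds named here, it differs from compound 3 by methoxy in place of hydrogen on an aromatic carbon, the same change as the one from compound 1 to compound 2, made at the same place, only on the core of compound 3 instead of the core of compound 1. Since the earlier instance of this change left no readable step, the expected step from compound 3 to compound 4 in this assay is estimated as small, a 1.2-fold lower number from compound 3 to compound 4 (0.06 log units; within the scatter), resting on compound 3 giving 28900 nM as the only anchor. Compound 4 is expected to give about 25000 nM, with a range from 8000 nM to 80000 nM.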

Compound 4, half-maximal inhibitory concentration: > 100000 nM
Compound 4: only a limit was reported; the forecaster's own chance of this, stated with the estimate: 20%; middle value at least 4.0-fold (0.60 log units) from the limit.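

In this assay, methoxy in place of hydrogen on the aromatic ring of the benzyl group gave an at least 3.4-fold higher number from compound 3 to compound 4 (0.53 log units; beyond the scatter), so on the core of compound 3 this change goes with weaker inhibition, and by more than the usual scatter. Going by these compounds, for compound 4 the value > 100000 nM is a limit of the assay, not a number, so the true size of the step stays unknown and only its smallest possible size is printed. This does not show whether the change acts alike on the two cores, since the step on the core of compound 1 has no readable size, and neither have the steps from compound 1 or compound 2 to compound 4, because all of these compounds end at the same limit: the limit of > 100000 nM in this assay, at which 3 of the 4 values shown sit.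

On these data alone, it remains open whether a chloro, hydroxy or amino group on the same aromatic carbon would keep the number close to that of compound 3, at 28900 nM, or whether the loss follows any group placed there. Also open, as far as these compounds go, is what a longer chain, such as phenethyl in place of benzyl on the amide nitrogen, would do in this assay.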